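This account rests on a few compounds, and the source may have more. Where it says the series, first, only, none or still open, it means among the compounds named here.

Measured compounds:
compound 1, `O=C(NCc1ccc(CNS(=O)(=O)c2ccc3c(c2)CCO3)cc1)c1scc2c1OCCO2`, gives 10 nM in an assay on cells for displacement of a labelled ligand from C-X-C chemokine receptor type 4 (Homo sapiens), read by fluorescence and microscopy, with stated times of 10 min and 30 min; on this read-out higher numbers stand for an effect only at larger amounts of compound and lower numbers for an effect already at smaller amounts
compound 2, `O=C(NCc1ccc(CNS(=O)(=O)c2cccc(F)c2)cc1)c1cc2ccccn2n1`, gives 1000 nM in this assay

Compound 2 stands at the highest of the two numbers; its nearest neighbour is compound 1, which sits a long way lower, a gap well beyond the usual scatter. Going by the values given here, compound 1 and compound 2 differ in two places, on the sulfonyl sulfur and on the amide side, so no single-change step between measured compounds is available.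

Compound 3, `O=C(NCc1ccc(CNS(=O)(=O)c2ccc3c(c2)CCO3)cc1)c1cc2ccccn2n1`, is not yet measured. It differs from compound 2 at one place only: a group of 9 heavy atoms (8 carbon, 1 oxygen; one five-membered non-aromatic ring with 1 hetero atom, one six-membered aromatic ring of carbon only) in place of a group of 7 heavy atoms (6 carbon, 1 fluorine; one six-membered aromatic ring of carbon only), on a sulfonyl sulfur. Among the compounds with values here, the entering group is the one compound 1 carries on its sulfonyl sulfur, where compound 1 gives 10 nM in this assay; yet compound 1 also differs from compound 3 on the amide side, so that value cannot be carried over directly.

The expectation is a step toward lower numbers, beyond the scatter: a 10-fold lower number from compound 2 to compound 3 (1.00 log units; beyond the scatter). Compound 3 is estimated at 100 nM, with a range from 20 nM to 600 nM.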

Compound 3, effective concentration (reported as EC, without a stated level of effect): 1 nM
Estimate against measurement, compound 3: 100-fold (2.00 log units) above; measured number outside the range, below it.
By their numbers in this assay, from the lowest: compound 3; then compound 1; then compound 2.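

In this assay, going by these compounds alone, the sulfonyl sulfur is now read in a single-place comparison for the first time: with the amide side held constant, replacing 3-fluorophenyl with the group carrying a five-membered non-aromatic ring and a six-membered aromatic ring gives a 1000-fold lower number from compound 2 to compound 3 (3.00 log units; beyond the scatter), a large step that the two earlier compounds, differing in two places, could not isolate. The amide side also proves to be a separate point of sensitivity: with that same group held on the sulfonyl sulfur, the change on the carbonyl carbon gives a 10-fold lower number from compound 1 to compound 3 (1.00 log units; beyond the scatter), a step classed as modest and still beyond the scatter, so both places affect the read-out in these compounds. No measurement is available that would tie either step to a cause or to any one feature of the groups exchanged.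

The compounds shown leave open whether the ring oxygen of the entering group is needed, which a methoxy group or an amine at the sulfonyl end would begin to test. They also leave open whether 3-fluorophenyl would give a step of similar size when paired with the amide side of compound 1.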